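Methyl to methoxy on the pendant ring: solubility notes

The source may hold more compounds than are shown below. What is called first, only, known or untested is meant among the compounds shown, and "the series" means these compounds.

Measured so far:
Compound 1, `CNC(=O)c1cc(C(=O)N[C@H]2CC[C@H](O)CC2)n([C@@H](C)c2cccc(Cl)c2)n1`, in a physicochemical assay for solubility, measured as kinetic solubility (on this read-out higher numbers stand for higher solubility and lower numbers for lower solubility), gives >= 143 ug/mL, which is a limit of the assay and not a number.
Compound 2, `CNC(=O)c1cc(C(=O)N[C@H]2CC[C@H](O)CC2)c([C@@H](C)c2cccc(C)c2)o1`, in this assay gives >= 172 ug/mL, again a limit of the assay rather than a number.

Among the measured compounds shown here, compound 2 therefore stands only at a limit; both values shown sit at limits (the limit of >= 143 ug/mL in this assay, at which 1 of the 2 values shown sits, and (the limit of >= 172 ug/mL in this assay, at which 1 of the 2 values shown sits)), so no step between measured compounds can be read, and the two structures differ in more than one place, so their values are simply two limits side by side.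

Compound 3, `CNC(=O)c1cc(C(=O)N[C@H]2CC[C@H](O)CC2)c([C@@H](C)c2cccc(OC)c2)o1`, has not yet been measured in this assay. It differs from compound 2 as follows: methoxy in place of methyl on an aromatic carbon. The change is a small one, a single heavy atom added and one hydrogen-bond acceptor gained, on the six-membered aromatic ring of carbon only.

For the measured compounds named here, with no measured step to lean on, the step of an at least 1.0-fold lower number from compound 2 to compound 3 (0.00 log units; that floor lies within the scatter) is expected to stay within the usual scatter, with no clear direction. Compound 3 is accordingly expected to give about 170 ug/mL in this assay, within 90 ug/mL to 250 ug/mL, and most likely again as a limit rather than a number.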

Compound 3, solubility: >= 113 ug/mL
Compound 3: a limit, no number; the forecaster's own chance of this, stated with the estimate: 70%; the middle value lies beyond the limit too.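

In this assay, among the compounds shown here, compound 2 and compound 3 both stand at limits of the assay and not at numbers, and no step between them can be read. The compounds shown leave open whether methoxy in place of methyl on the aromatic carbon shifts the read-out at all, and in which direction.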